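Trifluoromethylphenyl for Dichlorophenyl on the Aryl Amine Nitrogen

This account rests on a few compounds, and the source may have more. Where it says the series, first, only, none or still open, it means among the compounds named here.

Three compounds that share one core have been run in an ADME assay on cells (Hepatocyte, Homo sapiens) for metabolic stability, read by LC-MS, with a stated time of 60 min, tested at 1 uM; a higher number here means faster removal of the compound, a lower number slower removal. Compound 1 `COc1cc(N(CC2CC2)c2ccc(Cl)c3ccccc23)cnc1C(=O)[C@H]1C[C@@H]1C(=O)O` gives 5 uL/min in this assay. Compound 2 `COc1cc(N(CC2CC2)c2ccc(Cl)c(Cl)c2)cnc1C(=O)[C@H]1C[C@@H]1C(=O)O` gives 4.3 uL/min, and compound 3 `CCCN(c1cnc(C(=O)[C@H]2C[C@@H]2C(=O)O)c(OC)c1)c1ccc(F)c2ccccc12` gives 7.6 uL/min. Compound 2 sits at the bottom of these three numbers, yet its gaps to compound 1 and to compound 3 both lie within the usual scatter of repeated measurements, so the three values cannot be told apart.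

Compound 4 `COc1cc(N(CC2CC2)c2cccc(C(F)(F)F)c2)cnc1C(=O)[C@H]1C[C@@H]1C(=O)O` has not yet been measured. It differs from compound 2 in one place: 3-(trifluoromethyl)phenyl in place of 3,4-dichlorophenyl on a nitrogen on an aromatic ring

Among the measured compounds shown here, nothing among the measured compounds shows how a change of this kind moves this assay, and the three values present spread over a band no wider than the scatter. The step from compound 2 to compound 4 is therefore expected to be small, in no particular direction, and is estimated at a 1.2-fold higher number from compound 2 to compound 4 (0.07 log units; within the scatter). Compound 4 is expected to give about 5 uL/min in this assay, with a plausible range from 2.5 uL/min to 10 uL/min.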

Compound 4, intrinsic clearance in a liver preparation (reported as CLH), per the amount of preparation that the assay uses: 2.3 uL/min
Compound 4: middle estimate off by 2.2-fold (0.34 log units), on the high side; measured number below the stated range.
By their numbers in this assay, from the lowest: compounds 4, 2, 1 and 3 (each within the scatter of the next, the first and the last beyond it).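

In this assay, among the compounds shown here, the exchange of 3,4-dichlorophenyl for 3-(trifluoromethyl)phenyl on a nitrogen on an aromatic ring gives a 1.9-fold lower number from compound 2 to compound 4 (0.27 log units; within the scatter) and this is the first step at this position that can be read as a change in one place. The entering group carries 10 heavy atoms against 8 in the group that leaves, and this difference in size comes with a step that stays within the scatter, so the position tolerates this exchange without a clear shift in the read-out. No measurement on these compounds bears on what lies behind the step.

On these data alone, whether a nitrile on the phenyl ring in place of the trifluoromethyl would also stay within the scatter remains open. So does whether the same exchange would read alike with a longer chain on the nitrogen.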